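Pendant Ring Change: 3,4-Dichlorophenyl Replaces 3-Methoxyphenyl

The source may report more compounds than this note shows. Statements on the series, on what has been measured and on what is new or still open speak of the compounds shown alone.

Among the measured compounds shown here, compound 2 `C#CCNC1CCc2c(SCCc3cccc(OC)c3)cccc21` gives 28700 nM in an assay on isolated protein for inhibition of Amine oxidase [flavin-containing] B (Homo sapiens) (on this read-out lower numbers stand for stronger inhibition and higher numbers for weaker inhibition), the higher of the two numbers measured so far. For the measured compounds named here, compound 1 `C#CCNC1CCc2c(SCCc3ccc(Cl)cc3)cccc21` gives 10800 nM in this assay, and the only measured step, a 2.7-fold higher number from compound 1 to compound 2 (0.42 log units; beyond the scatter), is the one that bears on the change at hand. Compound 3 `C#CCNC1CCc2c(SCCc3ccc(Cl)c(Cl)c3)cccc21` differs from compound 2 by 3,4-dichlorophenyl in place of 3-methoxyphenyl on a saturated chain carbon, two bonds along the chain from a sulfur. Because compound 1 gives 10800 nM with its 4-chlorophenyl group, the expected step is back toward a lower number, a 3.6-fold lower number from compound 2 to compound 3 (0.55 log units; beyond the scatter). Compound 3 is thus estimated at 8000 nM, with a range from 3000 nM to 25000 nM.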

Compound 3, half-maximal inhibitory concentration: 3850 nM
The estimate for compound 3 lay 2.1-fold (0.32 log units) above the measured number; measured number inside the range.
By their numbers in this assay, from the lowest: compound 3; then compound 1; then compound 2.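

Swapping 3-methoxyphenyl for 3,4-dichlorophenyl gives a 7.5-fold lower number from compound 2 to compound 3 (0.87 log units; beyond the scatter) in this assay, the largest step so far at this position. Placing chloro in place of hydrogen on an aromatic carbon gives a 2.8-fold lower number from compound 1 to compound 3 (0.45 log units; beyond the scatter) and shows that a second chlorine on the ring goes with a further drop in the number. Nothing available explains either step.

Still open, on these data alone, is how 3-chlorophenyl, with its single chlorine in the other place, would compare. Also open, as far as these compounds go, is whether an amine on the ring or a longer chain to the sulfur would lower the number further.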